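Replacing the Urea with a Benzamide Group

The source may hold more compounds than are shown below. What is called first, only, known or untested is meant among the compounds shown, and "the series" means these compounds.

Among the measured compounds shown here, in a functional assay on 786-0 cells (Homo sapiens) for inhibition, read by sulforhodamine B assay, with a stated time of 48 h (a higher number here means a weaker inhibitor of growth, a lower number a stronger inhibitor of growth), compound 2 `COc1cc(-c2nn(-c3cccc(NC(=O)Nc4ccc(Cl)c(C(F)(F)F)c4)c3)cc2-c2ccncc2)ccc1Cl` gives 8020 nM, one of only two numbers measured so far; the other, for compound 1 `COc1cc(-c2nn(-c3cccc(NC(=O)Nc4cccc(C(F)(F)F)c4)c3)cc2-c2ccncc2)ccc1Cl`, is 4050 nM, which lies within the scatter of it. For the measured compounds named here, the single measured step, a 2.0-fold higher number from compound 1 to compound 2 (0.30 log units; within the scatter), touched a different part of the molecule. Compound 3 `COc1cc(-c2nn(-c3cccc(NC(=O)c4ccccc4)c3)cc2-c2ccncc2)ccc1Cl` carries phenyl in place of (4-chloro-3-(trifluoromethyl)phenyl)amino on a carbonyl carbon, on the carbonyl carbon whose other neighbour is an amide-type nitrogen. Going by the values given here, no measured step covers this change, so its direction cannot be read from the data. Compound 3 is expected to come out at 15000 nM, ranging from 4000 nM to 50000 nM. That estimate means a 1.9-fold higher number from compound 2 to compound 3 (0.27 log units; within the scatter).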

Compound 3, concentration for total growth inhibition: > 100000 nM
Compound 3 ended at the assay's limit (the forecaster's own chance of this, stated with the estimate: 15%); middle value at least 6.6-fold (0.82 log units) from the limit.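

Swapping the substituted phenylamino group on the carbonyl carbon for phenyl matters far more in this assay than the chloro change did: an at least 12-fold higher number from compound 2 to compound 3 (1.09 log units; beyond the scatter), and an at least 24-fold higher number from compound 1 to compound 3 (1.39 log units; beyond the scatter). The value of compound 3 is a limit of the assay, not a number: the limit of > 100000 nM in this assay, at which 1 of the 3 values shown sits. Both steps therefore give only a minimum size, and at this position the benzamide of compound 3 loses the measurable growth inhibition seen with the ureas.

This one change removes the amino link and the ring substituents together, and the compounds shown do not separate the two. Still open, on these data alone, is whether a benzamide whose phenyl carries trifluoromethyl and chloro groups, or a longer chain on the carbonyl carbon, would restore inhibition.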